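The source may hold more compounds than are shown below. What is called first, only, known or untested is meant among the compounds shown, and "the series" means these compounds.

Values in a physicochemical assay for solubility; a higher number here means a more soluble compound, a lower number a less soluble compound (each one a limit, not a number)

- Compound 1 `CNC(=O)c1cc(C(=O)N[C@H]2[C@@H]3COC[C@@H]32)cc2c1OC[C@@]2(CO)c1ccccc1` gives >= 202 ug/mL
- Compound 2 `CC[C@@]1(c2ccccc2)COc2c(C(=O)NC)cc(C(=O)N[C@H]3[C@@H]4COC[C@@H]43)cc21` gives >= 152 ug/mL
- Compound 3 `CNC(=O)c1cc(C(=O)N[C@H]2[C@@H]3COC[C@@H]32)cc2c1OC[C@@]2(C)c1ccccc1` gives >= 147 ug/mL

Compound 3 sits at >= 147 ug/mL which is a limit and not a number. The other two compounds also give only limits, so no firm ranking can be made.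

Compound 4 `CNC(=O)c1cc(C(=O)NC2CC2)cc2c1OC[C@@]2(C)c1ccccc1` differs from compound 3 in one place (a group of 3 heavy atoms (3 carbon; one three-membered non-aromatic ring of carbon only) in place of a group of 6 heavy atoms (5 carbon, 1 oxygen; one three-membered non-aromatic ring of carbon only, one five-membered non-aromatic ring with 1 hetero atom), on an amide-type nitrogen) and cyclopropyl now stands on the amide-type nitrogen.

Three steps have been measured (a step that the two limits leave unreadable from compound 1 to compound 2 and a step that the two limits leave unreadable from compound 1 to compound 3 and a step that the two limits leave unreadable from compound 2 to compound 3) but they concern a saturated chain carbon bound to a saturated ring carbon, not the amide-type nitrogen. None of them offers a size to carry over.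

The direction in this assay is therefore only a cautious guess, and a modest fall is expected. The expected step is an at least 1.3-fold lower number from compound 3 to compound 4 (0.12 log units; that floor lies within the scatter) and this remains an estimate. For compound 4 the estimated value is 110 ug/mL in this assay as a central figure. The expected range for compound 4 runs from 35 ug/mL to 220 ug/mL and is kept wide.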

Compound 4, solubility: >= 138 ug/mL
Compound 4 ended at the assay's limit; the forecaster's own chance of this, stated with the estimate: 40%; middle value at least 1.2-fold (0.09 log units) from the limit.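

In this assay compound 4 gives >= 138 ug/mL, which is a limit and not a number. Compound 3 also gives only a limit, so the step between compound 3 and compound 4 cannot be read. The compounds shown leave open whether cyclopropyl on the amide-type nitrogen changes the read-out at all.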